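The compounds below may be only part of what the source reports. "The series", "measured", "known", "first", "only" and "open" are said of these compounds alone.

Compound 1 `COc1ccc(C2=NN(C3=NC(=O)/C(=C4\C(=O)Nc5ccc(Br)cc54)S3)C(c3ccc(Cl)cc3)C2)cc1` gives 120 nM in a functional assay on cells (Cancer cell lines, Homo sapiens) for cytotoxicity, read by sulforhodamine B assay, with a stated time of 48 h; a lower number here means a stronger inhibitor of growth, a higher number a weaker inhibitor of growth.
Compound 2 `COc1ccc(C2=NN(C3=NC(=O)/C(=C4\C(=O)Nc5ccc(Cl)cc54)S3)C(c3ccc(Cl)cc3)C2)cc1` gives 200 nM in this assay.
Compound 3 `CN(C)c1ccc(C2CC(c3ccccc3)=NN2C2=NC(=O)/C(=C3\C(=O)Nc4ccc(Br)cc43)S2)cc1` gives 220 nM in this assay.

Compounds 1 and 2 differ in one place only: chloro in place of bromo on an aromatic carbon. That change made a step of a 1.7-fold higher number from compound 1 to compound 2 (0.22 log units; within the scatter). Compound 3 carries a different core; how its core differs from the core of compound 1 is not broken down here. Compound 4 `CN(C)c1ccc(C2CC(c3ccccc3)=NN2C2=NC(=O)/C(=C3\C(=O)Nc4ccc(Cl)cc43)S2)cc1` has not yet been measured. It stands to compound 3 exactly as compound 2 stands to compound 1, the same change at the same place: chloro in place of bromo on an aromatic carbon. From compound 3 to compound 4 a step of about a 1.5-fold higher number from compound 3 to compound 4 (0.16 log units; within the scatter) is expected in this assay, and that expectation rests on a 1.7-fold higher number from compound 1 to compound 2 (0.22 log units; within the scatter). Compound 4 is therefore estimated at 320 nM, with a likely range from 150 nM to 700 nM.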

Compound 4, concentration for 50% growth inhibition: 210 nM
The estimate for compound 4 lay 1.5-fold (0.18 log units) above the measured number; the measured number falls inside the stated range.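

Chloro in place of bromo on an aromatic carbon gives a 1.0-fold lower number from compound 3 to compound 4 (0.02 log units; within the scatter) in this assay. Set beside the earlier step, the exchange reads no differently on the two cores: the same change on two cores in this assay, a 1.7-fold higher number (0.22 log units; within the scatter) from compound 1 to compound 2 and a 1.0-fold lower number (0.02 log units; within the scatter) from compound 3 to compound 4, 1.7-fold (0.24 log units) apart, within the scatter of two such steps. Both steps therefore show that this exchange can be carried between these two cores without a difference that rises above the scatter, but they give it no reliable direction or size and say nothing about any further core.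

The compounds shown hold only bromo and chloro at this place. As far as these compounds go, whether fluoro, a nitro group or an amine there would read like them in this assay remains open.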